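The compounds below may be only part of what the source reports. "The series", "measured", "known", "first", "only" and "open" are said of these compounds alone.

In a functional assay on P388 cells (Mus musculus) for antiproliferative activity (a higher number here means a weaker inhibitor, a lower number a stronger inhibitor), compound 1 `Nc1ccc(S(=O)(=O)Nc2cccc3cc[nH]c23)cc1` gives 14 ug/mL while compound 2 `COc1ccc(S(=O)(=O)Nc2cccc3c(C#N)c[nH]c23)cc1` gives 0.17 ug/mL and so holds the lower of the two numbers, a gap beyond the usual scatter. Compound 3 `CS(=O)(=O)Nc1ccc(S(=O)(=O)Nc2cccc3c(C#N)c[nH]c23)cc1` is still unmeasured. It carries methanesulfonamido in place of methoxy on an aromatic carbon, para to a large group (methanesulfonamido in place of methoxy on an aromatic carbon). Within the data shown here, no single-change step has been measured here, so only a modest weakening is expected, with a 2.4-fold higher number from compound 2 to compound 3 (0.37 log units; beyond the scatter) as the estimated step, near the edge of the scatter. The estimated value for compound 3 is 0.4 ug/mL with an expected range of 0.1 ug/mL to 2 ug/mL in this measurement.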

Compound 3, half-maximal inhibitory concentration: 3.5 ug/mL
The estimate for compound 3 lay 8.8-fold (0.94 log units) below the measured number, outside the stated range (above it).
By their numbers in this assay, from the lowest: compound 2; then compound 3; then compound 1.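

In this assay, methanesulfonamido in place of methoxy gives a 21-fold higher number from compound 2 to compound 3 (1.31 log units; beyond the scatter), a large step. Among these compounds, this is the first single-change step available, and it shows that the group on this aromatic carbon, para to a large group, can alone move the number well beyond the scatter. No measurement here explains the loss. From the compounds shown here alone, whether ethoxy or a carboxylic acid on this carbon would stay close to compound 2 remains open. One pair also cannot separate the effect of the extra heavy atoms from that of the added hydrogen-bond donor.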